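A few compounds are considered here, and "the series" means these few. Any claim that something is new, unique, unknown or untested is made for them only; others in the source may bear on it.

Measured so far in a functional assay on K562 cells (Homo sapiens) for cytotoxicity, read by trypan blue exclusion, with a stated time of 96 h; on this read-out lower numbers stand for stronger inhibition and higher numbers for weaker inhibition:
- compound 1 `COc1ccc(NS(=O)(=O)/C=C/c2c(OC)cc(OC)cc2OC)cc1`: 75 nM
- compound 2 `COc1cc(OC)c(/C=C/S(=O)(=O)Nc2ccc(OC)c(OP(=O)(O)O)c2)c(OC)c1`: 7.5 nM

Compound 2 has the lower of the two numbers, and its gap to compound 1 lies beyond the scatter. Next in line is compound 3 `COc1cc(OC)c(/C=C/S(=O)(=O)Nc2ccc(OC)c([N+](=O)[O-])c2)c(OC)c1`, which differs from compound 2 at one place: a group of 3 heavy atoms (1 nitrogen, 2 oxygen; no ring) in place of a group of 5 heavy atoms (4 oxygen, 1 phosphorus; no ring), on an aromatic carbon. Among the compounds with values here, the group that leaves is the one whose arrival defines the only measured step, a 10-fold lower number from compound 1 to compound 2 (1.00 log units; beyond the scatter). That single pair is all that bears on the change, and it shows how far the number moved when hydrogen gave way to this group on that aromatic carbon. Within the data shown here, no measured compound carries a nitro, so the data do not show whether nitro tracks hydrogen or the group it replaces. Without that group the number stands at the level of compound 1, 75 nM, and this serves as a rough guide to the expected direction. An expected 4.0-fold higher number from compound 2 to compound 3 (0.60 log units; beyond the scatter) is estimated, moving towards weaker inhibition but probably not the whole way back. For compound 3 the estimated value is 30 nM, with an expected range of 6 nM to 150 nM.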

Compound 3, half-maximal inhibitory concentration: 1000 nM
Beside the measured number, compound 3's estimate is 33-fold (1.52 log units) below it; measured number above the stated range.
By their numbers in this assay, from the lowest: compound 2; then compound 1; then compound 3.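

In this assay, the aromatic carbon ortho to a methoxy group now proves sensitive in both directions: the earlier pair showed only a move towards stronger inhibition, whereas nitro in place of hydrogen gives a 13-fold higher number from compound 1 to compound 3 (1.12 log units; beyond the scatter), a move towards weaker inhibition. Hydrogen therefore sits between the two other groups, and the result of exchanging them directly, a 130-fold higher number from compound 2 to compound 3 (2.12 log units; beyond the scatter), is the widest span in this small set, so the identity of the group at this place matters far more than compound 1 and compound 2 alone could show. No available measurement accounts for either direction of change.

On these data alone, three groups at one position on one core give an order but no trend, and it remains open whether nitro or the group of oxygen and phosphorus is the outlier relative to hydrogen. An amine, a hydroxyl or a carboxylic acid on the same aromatic carbon would show where other groups fall within this range, and whether compound 3 marks its weak end.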